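The source may report more compounds than this note shows. Statements on the series, on what has been measured and on what is new or still open speak of the compounds shown alone.

Measured so far in a physicochemical assay for lipophilicity, read by HPLC, in phosphate buffer, measured as octanol-water partition, at pH 7.4, tested at 100 uM; a lower number here means a more polar compound, a higher number a more lipophilic compound:
Compound 1 `COCCOc1cc(C)c(-c2cccc(CNc3ccc(OCC(=O)O)c(F)c3)c2)c(C)c1` gives 2.47
Compound 2 `O=C(O)COc1ccc(NCc2cccc(-c3ccccc3Cl)c2)cc1F` gives 2.71
Compound 3 `CC(C)c1ccccc1-c1cccc(CNc2ccc(OCC(=O)O)c(F)c2)c1` gives 3.45

Compound 3 is the highest of these three, and both other compounds lie clearly lower. The next structure, compound 4 `Cc1ccc(-c2cccc(CNc3ccc(OCC(=O)O)c(F)c3)c2)c(Cl)c1`, has 2-chloro-4-methylphenyl in place of 2-isopropylphenyl on an aromatic carbon, meta to a large group: 2-chloro-4-methylphenyl in place of 2-isopropylphenyl on an aromatic carbon.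

Within the data shown here, only one measured step bears on this change. It is the step of a number 0.74 log units higher from compound 2 to compound 3 (beyond the scatter), which put isopropyl in place of chloro on an aromatic carbon. That step was modest but beyond the scatter. Compound 4 partly reverses that swap, since chloro returns. Going by a number 0.74 log units higher from compound 2 to compound 3 (beyond the scatter), a return to chloro alone would point downward by about that size. However, compound 4 also carries a methyl group that compound 2 lacks, and no measured step shows what a methyl does in this assay. The outcome is therefore less certain than a simple reversal, and a smaller downward step seems the reasonable expectation.

The expected step is a number 0.35 log units lower from compound 3 to compound 4 (beyond the scatter), and this is only an estimate. For compound 4 the estimated value is 3.1, with an expected range from 2.75 to 3.45.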

Compound 4, distribution coefficient: 3.24
Compound 4: the middle estimate sits 0.14 log units below what was measured, and the stated range covers the measured number.
By their numbers in this assay, from the lowest: compounds 1 and 2 (each within the scatter of the next); then compounds 4 and 3 (each within the scatter of the next).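

In this assay, among these compounds, the change of methyl in place of hydrogen on an aromatic carbon gives a number 0.53 log units higher from compound 2 to compound 4 (beyond the scatter) and is the first measured reading of what a methyl does here, modest in size but clear of the usual scatter. Putting 2-chloro-4-methylphenyl in place of 2-isopropylphenyl on this aromatic carbon gives a number 0.21 log units lower from compound 3 to compound 4 (within the scatter) and leaves the two groups indistinguishable at this position, whereas chloro alone in place of isopropyl stood apart, as the step of a number 0.74 log units higher from compound 2 to compound 3 (beyond the scatter) shows when read in reverse. Nothing available here gives a reason for either of the new steps.

From the compounds shown here alone, the methyl has been read only once, at a single place on a single background, so it remains open whether a similar step would appear at another aromatic carbon or alongside a group other than chloro. Going by these compounds, how trifluoromethyl, a nitrile or an amine would shift the number at this position also remains open.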